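The compounds below may be only part of what the source reports. "The series", "measured", "known", "first", "only" and "open" are said of these compounds alone.

Compound 1 `COc1ccc(C(=O)/C=C/c2cc3ccccc3[nH]c2=O)cc1`: 3410 nM
Compound 2 `O=C(/C=C/c1cc2ccccc2[nH]c1=O)c1ccc(O)cc1`: 1890 nM

Within the data shown here, in a functional assay on SW-620 cells (Homo sapiens) for cytotoxicity, read by sulforhodamine B assay, with a stated time of 24 h (on this read-out lower numbers stand for stronger inhibition of growth and higher numbers for weaker inhibition of growth), compound 2 gives the lower of the two numbers measured so far, but its only neighbour lies close: a 1.8-fold lower number from compound 1 to compound 2 (0.26 log units; within the scatter), so nothing can be read from this pair beyond the scatter of the measurement. Compound 3 `O=C(/C=C/c1cc2ccccc2[nH]c1=O)c1ccc(Cl)cc1` is not yet measured. It differs from compound 2 in one place: chloro in place of hydroxy on an aromatic carbon. Among the measured compounds shown here, the single measured step concerns hydrogen in place of methyl on an oxygen on an aromatic ring, a change of a different kind from the exchange of hydroxy for chloro, and it stayed within the scatter. For the measured compounds named here, no measured step exchanges hydroxy for chloro, so the data give no direction for this change. For compound 3 a number in the same region as compound 2 is therefore expected, with a wide range to reflect the missing precedent: 2000 nM, between 600 nM and 7000 nM, meaning an expected step of a 1.1-fold higher number from compound 2 to compound 3 (0.02 log units; within the scatter).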

Compound 3, concentration for 50% growth inhibition: 3380 nM
Estimate against measurement, compound 3: 1.7-fold (0.23 log units) below; measured number inside the range.
By their numbers in this assay, from the lowest: compounds 2, 3 and 1 (each within the scatter of the next).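

In this assay, the exchange of hydroxy for chloro on the aromatic carbon para to a large group gives a 1.8-fold higher number from compound 2 to compound 3 (0.25 log units; within the scatter), and the exchange of methoxy for chloro gives a 1.0-fold lower number from compound 1 to compound 3 (0.00 log units; within the scatter). This position has now carried three different groups, and the numbers do not separate them, even though chloro brings 0 hydrogen-bond donors and 0 hydrogen-bond acceptors where hydroxy brings 1 of each. Nothing available explains why these three compounds read alike.

As far as these compounds go, whether an amine, a carboxylic acid or a longer chain at this position would move the number beyond the scatter remains open. Also open, from the compounds shown here alone, is whether a change elsewhere on the shared core would matter more than any change at this position.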